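From 3-(methoxymethoxy)phenyl to 4-chlorophenyl in one step

The compounds below may be only part of what the source reports. "The series", "measured", "known", "first", "only" and "open" are said of these compounds alone.

In a functional assay on MCF7 cells (Homo sapiens) for inhibition, read by MTT assay, with a stated time of 3 days (on this read-out higher numbers stand for weaker inhibition and lower numbers for stronger inhibition), compound 1 (`C/C=C/COc1cc(/C=C\c2cc(OC)c(OC)c(OC)c2)ccc1OC`) gives 5400 nM and compound 2 (`COCOc1cccc(/C=C/CCCOc2cc(/C=C\c3cc(OC)c(OC)c(OC)c3)ccc2OC)c1`) gives 8000 nM as its value. These two numbers lie within the usual scatter of each other, so compound 2 cannot be separated from compound 1 on this evidence.

Among the compounds with values here, compound 3 (`COc1ccc(/C=C\c2cc(OC)c(OC)c(OC)c2)cc1OCCC/C=C/c1ccc(Cl)cc1`) has no measurement yet. It differs from compound 2 in one place, with 4-chlorophenyl in place of 3-(methoxymethoxy)phenyl on a double-bonded chain carbon bound to a double-bonded chain carbon.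

Within the data shown here, no measured pair shows this swap directly. Among the measured compounds shown here, the only guide is that compound 1 at 5400 nM and compound 2 at 8000 nM stay within the scatter despite their different side chains. The expected 1.5-fold lower number from compound 2 to compound 3 (0.16 log units; within the scatter) is therefore small, toward a lower number, and not beyond the scatter. In this assay compound 3 is expected at 5500 nM within a range of 1800 nM to 16000 nM as estimated here.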

Compound 3, half-maximal inhibitory concentration: 40000 nM
Beside the measured number, compound 3's estimate is 7.3-fold (0.86 log units) below it; the whole stated range lies below it.
By their numbers in this assay, from the lowest: compounds 1 and 2 (each within the scatter of the next); then compound 3.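

In this assay, the group carried on this double-bonded chain carbon does matter: 4-chlorophenyl in place of 3-(methoxymethoxy)phenyl gives a 5.0-fold higher number from compound 2 to compound 3 (0.70 log units; beyond the scatter) and so weakens inhibition. Compounds 1 and 2 could not be told apart despite their different side chains, so they gave no sign that the side chain matters, but 4-(4-chlorophenyl)but-3-en-1-yl in place of prop-1-en-1-yl gives a 7.4-fold higher number from compound 1 to compound 3 (0.87 log units; beyond the scatter) and shows that not every side chain is tolerated equally. Nothing available here explains why the 4-chlorophenyl end behaves this way.

The compounds shown cannot separate the effect of adding the chlorine from that of removing the methoxymethoxy group. As far as these compounds go, a plain phenyl, or a ring carrying a hydroxyl or an amine, would help to separate them, and how a shorter chain would behave also remains open.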